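A few compounds are considered here, and "the series" means these few. Any claim that something is new, unique, unknown or untested is made for them only; others in the source may bear on it.

Compound 3 `COc1ccc(/C=C\C(=O)O)c(OCc2cn(-c3ccccc3)nn2)c1CC=C(C)C` stands beside compound 2 `COc1ccccc1-n1cc(COc2c(/C=C\C(=O)O)ccc(OC)c2CC=C(C)C)nn1` and compound 1 `COc1ccc(/C=C\C(=O)O)c(OCc2cn(-c3ccc(NC(C)=O)cc3)nn2)c1CC=C(C)C`. In a functional assay on HCT-116 cells (Homo sapiens) for cytotoxicity, read by MTT assay, with a stated time of 24 h (a higher number here means a weaker inhibitor, a lower number a stronger inhibitor), compound 1 gives "not determined" (no result reported), while compound 2 gives 32200 nM. In this assay compound 3 gives 26000 nM, a number within the scatter of compound 2. Compound 4 `COc1ccc(-n2cc(COc3c(/C=C\C(=O)O)ccc(OC)c3CC=C(C)C)nn2)cc1` differs from compound 3 by methoxy in place of hydrogen on an aromatic carbon, sitting on an aromatic carbon of a six-membered aromatic ring of carbon only, para to a large group; cut one bond further out, phenyl becomes 4-methoxyphenyl. Among the compounds with values here, the only step that bears on it is a 1.2-fold lower number from compound 2 to compound 3 (0.09 log units; within the scatter), a methoxy removed from that same ring, which stayed within the scatter. Adding a methoxy on that ring is therefore expected to change little, and compound 4 is estimated at 28000 nM, between 12000 nM and 65000 nM, a step of a 1.1-fold higher number from compound 3 to compound 4 (0.03 log units; within the scatter).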

Compound 4, half-maximal inhibitory concentration: 8700 nM
Estimate against measurement, compound 4: 3.2-fold (0.51 log units) above; measured number below the stated range.
By their numbers in this assay, from the lowest: compound 4; then compounds 3 and 2 (each within the scatter of the next).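

The methoxy is not silent on every carbon of this ring: placed para to a large group, it gives a 3.0-fold lower number from compound 3 to compound 4 (0.48 log units; beyond the scatter) in this assay, whereas the methoxy of compound 2 left that compound within the scatter of compound 3. Its place on the ring therefore counts, since moving it to give 4-methoxyphenyl in place of 2-methoxyphenyl yields a 3.7-fold lower number from compound 2 to compound 4 (0.57 log units; beyond the scatter) as well. Nothing available accounts for this difference. From the compounds shown here alone, whether a hydroxyl, an ethoxy or an amine on that same carbon would give a comparable step remains open.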